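The compounds below may be only part of what the source reports. "The series", "measured", "known", "first", "only" and "open" are said of these compounds alone.

Measured compounds:
Compound 1 `O=C(O)CC/C=C\CO[C@H]1C(OCc2ccc(-c3ccccc3)cc2)CC[C@@H]1N1CCCCCC1` gives 12.6 nM in a functional assay on blood for antagonist activity at thromboxane A2 receptor (Homo sapiens); a higher number here means weaker binding, a lower number tighter binding.
Compound 2 `O=C(O)CC/C=C\CO[C@H]1C(OCc2ccc(-c3ccccc3)cc2)CC[C@@H]1N1CCCCC1` gives 63.1 nM; 15.9 nM (2 entries) in this assay.

Among the compounds with values here, compound 1 is the only compound here with a single number in this assay; a further entry for it carries no number. Compound 2 is represented by several entries whose spread, (the several entries of compound 2 in this assay, 63.1 nM; 15.9 nM (2 entries)), shows how far repeated values of this kind can drift, and compound 1 lies in the region of the tighter of those entries.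

Compound 3 `NC(=O)Cc1ccccc1-c1ccc(COC2CC[C@H](N3CCCCCC3)[C@H]2OC/C=C\CCC(=O)O)cc1` follows from compound 1 by one change: carbamoylmethyl in place of hydrogen on an aromatic carbon. Within the data shown here, no measured pair shows this change, so its effect is not known from these data. In this assay the step from compound 1 to compound 3 is expected to be small, a modest weakening at most, and possibly none beyond the usual scatter. Compound 3 is therefore estimated at 20 nM, within a range from 5 nM to 80 nM, which corresponds to an expected step of a 1.6-fold higher number from compound 1 to compound 3 (0.20 log units; within the scatter).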

Compound 3, dissociation constant: 7.94 nM
Compound 3: middle estimate off by 2.5-fold (0.40 log units), on the high side; the range from low to high includes it.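

Compound 1 and compound 2 carry only hydrogen on this aromatic carbon, ortho to a large group, so they could not show whether the place accepts a substituent. In this assay, carbamoylmethyl at this place gives a 1.6-fold lower number from compound 1 to compound 3 (0.20 log units; within the scatter), so this group is accepted there with no loss of binding beyond the scatter. The step is also smaller than the drift among repeated values of this kind: the several entries of compound 2 in this assay, 63.1 nM; 15.9 nM (2 entries).

Whether other groups are accepted at this place stays open, since a carboxylic acid, an amine or a longer chain on this aromatic carbon appears nowhere among these compounds. Also open, going by these compounds, is whether carbamoylmethyl would behave the same way on the core of compound 2.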